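Isopropyl Ester in Place of a Larger Ester Group

This account rests on a few compounds, and the source may have more. Where it says the series, first, only, none or still open, it means among the compounds named here.

Compound 1 `C[C@@H](O)[C@H]1C(=O)N2C(C(=O)OCOC(=O)C(C)(C)C)=C(S[C@@H]3CN[C@H](C(=O)Nc4cccc(C(=O)O)c4)C3)[C@H](C)[C@H]12` is examined in a physicochemical assay for metabolic stability, read by LC-MS, in phosphate buffer, with a stated time of 3 h, at pH 7.4, tested at 50 uM; a lower number here means that less of the compound is left, a higher number that more of the compound is left. In this assay compound 1 gives > 95%, which is a limit of the assay rather than a number. Two further compounds share this outcome. Compound 2 `C[C@@H](O)[C@H]1C(=O)N2C3=C(S[C@@H]4CN[C@@H](C4)C(=O)Nc4cccc(c4)C(=O)OCOCOC3=O)[C@H](C)[C@H]12` gives > 95% in this assay, again a limit. Compound 3 `C[C@@H](O)[C@H]1C(=O)N2C(C(=O)OCOC(=O)C(C)(C)C)=C(S[C@@H]3CN[C@H](C(=O)Nc4cccc(C(=O)OCOC(=O)C(C)(C)C)c4)C3)[C@H](C)[C@H]12` gives > 95% in this assay, also a limit. Going by the values given here, the one measured step, from compound 1 to compound 3, reads a step that the two limits leave unreadable from compound 1 to compound 3, and with both ends at the limit its size cannot be read. Every measured value sits at the same point (the limit of > 95% in this assay, at which 3 of the 3 values shown sit), so compound 1 stands where all the measured compounds stand.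

Compound 4 `CC(C)OC(=O)C1=C(S[C@@H]2CN[C@H](C(=O)Nc3cccc(C(=O)O)c3)C2)[C@H](C)[C@@H]2[C@@H]([C@@H](C)O)C(=O)N12` has not been measured. It differs from compound 1 in one place: isopropyl in place of (((tert-butyl)carbonyl)oxy)methyl on an oxygen next to a carbonyl group. Among the compounds with values here, no measured step alters this position in the same way, and the only step on hand is unreadable. With every measured compound at the limit, the expected step in this assay is a step that the limit leaves unreadable from compound 1 to compound 4, nothing beyond the scatter. Compound 4 is therefore estimated at 96%, with a range from 88% to 100%.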

Compound 4, percent of the compound remaining: > 95%
Compound 4 ended at the assay's limit; the forecaster's own chance of this, stated with the estimate: 75%; the middle value is on the limit's open side.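

No new step can be read from compound 1 to compound 4, because both values are limits rather than numbers: the limit of > 95% in this assay, at which 4 of the 4 values shown sit. The compounds shown leave open how much of each compound truly remains, and so whether isopropyl and (((tert-butyl)carbonyl)oxy)methyl differ in this assay at all.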